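Series notes: chain-end swap from acetoxy to methanesulfonamido

The source may hold more compounds than are shown below. What is called first, only, known or untested is meant among the compounds shown, and "the series" means these compounds.

The shared core carries an amide-linked saturated ring with a pendant dihalophenyl group and a chain on the ring. Compound 1 `Cn1ncc(Cl)c1-c1cc(C(=O)N[C@@H]2CN[C@H](CCn3cncn3)C[C@H]2c2ccc(Cl)c(Cl)c2)oc1Cl`, compound 2 `CC(=O)OCC[C@@H]1C[C@@H](c2ccc(F)c(F)c2)[C@H](NC(=O)c2cc(-c3c(Cl)cnn3C)c(Cl)o2)CN1` and compound 3 `Cn1ncc(Cl)c1-c1cc(C(=O)NC2CNCC2c2ccc(C(F)(F)F)cc2)oc1Cl` have been measured in an assay for inhibition of RAC-alpha serine/threonine-protein kinase (Homo sapiens), read by HTRF, with a stated time of 1 h; a higher number here means a weaker inhibitor, a lower number a stronger inhibitor. Compound 2 gives 3.4 nM, indistinguishable within the scatter from compound 1, which gives 4.47 nM. Compound 3, which lacks the chain and carries a trifluoromethyl group on its phenyl ring instead of two halogens, gives 538 nM, a gap beyond the scatter. Compound 4 `Cn1ncc(Cl)c1-c1cc(C(=O)N[C@@H]2CN[C@H](CCNS(C)(=O)=O)C[C@H]2c2ccc(F)c(F)c2)oc1Cl` is not yet measured. It differs from compound 2 at the chain end: methanesulfonamido in place of acetoxy on a saturated chain carbon, two bonds along the chain from a saturated ring carbon. For the measured compounds named here, no step between measured compounds isolates this kind of change. Because compound 1 gives 4.47 nM with a quite different chain end and still sits with compound 2, the step of a 1.3-fold higher number from compound 2 to compound 4 (0.12 log units; within the scatter) is expected to be small, in no clear direction, and within the scatter. For compound 4 the estimate in this assay is 4.5 nM, with a range from 1.5 nM to 14 nM.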

Compound 4, half-maximal inhibitory concentration: 3.29 nM
For compound 4 the middle estimate is 1.4-fold (0.14 log units) above the measured one; the range from low to high includes it.
By their numbers in this assay, from the lowest: compounds 4, 2 and 1 (each within the scatter of the next); then compound 3.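

In this assay, for the compounds shown here, the swap of acetoxy for methanesulfonamido, on a saturated chain carbon two bonds along the chain from a saturated ring carbon, gives a 1.0-fold lower number from compound 2 to compound 4 (0.01 log units; within the scatter) and is the first step to isolate a change at this chain end. The entering group adds a hydrogen-bond donor and a sulfur atom, and the number still stays within the scatter, so this position accepts both chain ends without a readable loss. The data offer no measured basis for explaining this result.

On these data alone, whether the same holds for a primary amine or a carboxylic acid at the chain end remains open. Also open, as far as these compounds go, is whether a longer chain carrying methanesulfonamido keeps the number in this range.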